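Swapping the Ether Linker for a Sulfur Bridge

The source may hold more compounds than are shown below. What is called first, only, known or untested is meant among the compounds shown, and "the series" means these compounds.

The measured compounds and their values:

Compound 1, `Nc1cc(N)c2nc(-c3ccccc3)c(NCc3ccc(Cl)c(Cl)c3)nc2c1`: 18600 nM
Compound 2, `Nc1cc(N)c2nc(-c3ccccc3)c(Oc3ccc(F)cc3)nc2c1`: 19500 nM
Compound 3, `CCOC(=O)[C@H](CCC(=O)O)NC(=O)c1ccc(Oc2nc3cc(N)cc(N)c3nc2-c2ccccc2)cc1`: 14500 nM

All three were tested in a functional assay on SK-MEL-28 cells (Homo sapiens) for inhibition, read by sulforhodamine B assay, with a stated time of 48 h; on this read-out lower numbers stand for stronger inhibition of growth and higher numbers for weaker inhibition of growth. On these numbers compound 2 stands highest, but its distance to compound 1 and to compound 3 is within the scatter of repeated measurements, so the three cannot be told apart; none of them is stronger or weaker than the others on this evidence. The shared core of the three is plain: a fused two-ring system carrying two amino groups and a phenyl group, and the compounds differ in what hangs from the aromatic carbon next to the ring nitrogen.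

Compound 4, `COc1ccc(Sc2nc3cc(N)cc(N)c3nc2-c2ccccc2)cc1`, is not yet measured. It differs from compound 2 as follows: (4-methoxyphenyl)sulfanyl in place of 4-fluorophenoxy on an aromatic carbon. The change replaces the oxygen link with a sulfur link and trades a fluorine for a methoxy group on the outer ring.

Going by the values given here, no step between two measured compounds isolates such a change, so nothing measured points in either direction. Since the three measured compounds, carrying three rather different groups at this position, all sit within the scatter of one another, the expectation for compound 4 in this assay is a step of no size beyond the scatter, a 1.2-fold lower number from compound 2 to compound 4 (0.09 log units; within the scatter). Compound 4 is therefore estimated at 16000 nM, with a range from 6000 nM to 42000 nM.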

Compound 4, concentration for 50% growth inhibition: 24500 nM
Estimate against measurement, compound 4: 1.5-fold (0.19 log units) below; measured number inside the range.
By their numbers in this assay, from the lowest: compounds 3, 1, 2 and 4 (each within the scatter of the next).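

In this assay, putting (4-methoxyphenyl)sulfanyl in place of 4-fluorophenoxy gives a 1.3-fold higher number from compound 2 to compound 4 (0.10 log units; within the scatter), so the two compounds cannot be told apart. Unlike the looser comparison among the earlier compounds, this is a single step between close relatives, and it shows that the group on this aromatic carbon next to the ring nitrogen can take a sulfur link and a methoxy group on its outer ring while the number stays within the scatter of the one for the group it replaces. No other measurement bears on this result, and it comes with no explanation.

The link and the outer-ring substituent change together in this step, which leaves open what each does alone: a sulfur link that keeps the fluorine, or an oxygen link that carries the methoxy group, would separate the two. Also open, from the compounds shown here alone, is whether a quite different group at this place, such as a piperazine ring or a nitrile on the outer ring, would give a step beyond the scatter in this assay.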